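This account rests on a few compounds, and the source may have more. Where it says the series, first, only, none or still open, it means among the compounds named here.

Working notes on the series. Compound 1 is `CC1=C(C(=O)OCc2cccnc2)C(c2ccccc2[N+](=O)[O-])C2=C(CCCC2=O)N1`, compound 2 is `COc1ccc(C2C(C(=O)OCc3cccnc3)=C(C)NC3=C2C(=O)CCC3)cc1`, compound 3 is `COc1ccc(C2C(C(=O)OCc3ccccn3)=C(C)NC3=C2C(=O)CCC3)cc1`, and compound 4, still to be measured, is `CC1=C(C(=O)OCc2ccccn2)C(c2ccccc2[N+](=O)[O-])C2=C(CCCC2=O)N1`. In a physicochemical assay for lipophilicity, measured as octanol-water partition (a lower number here means a more polar compound, a higher number a more lipophilic compound), compound 1 gives 1.51, compound 2 gives 1.54, and compound 3 gives 1.9. Compound 3 carries the highest of the three numbers, with compound 2 nearest to it and compound 1 furthest.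

Two changes are measured. From compound 2 to compound 1 the change is 2-nitrophenyl in place of 4-methoxyphenyl on a saturated ring carbon, and it moved this assay by a number 0.03 log units lower from compound 2 to compound 1 (within the scatter). The two cores of compound 2 and compound 3 differ as pyridin-2-yl in place of pyridin-3-yl on a saturated chain carbon bound to an oxygen next to a carbonyl group, and that moved the partition coefficient by a number 0.36 log units higher from compound 2 to compound 3 (beyond the scatter).

Compound 4 stands to compound 3 as compound 1 stands to compound 2: the change is 2-nitrophenyl in place of 4-methoxyphenyl on a saturated ring carbon, the second time this change occurs among the compounds shown. It is the same kind of change rather than the same one, since in compound 3 the saturated ring carbon sits next to the ring atom that bears a ((pyridin-2-yl)methoxy)carbonyl group, while in compound 2 that ring atom bears a ((pyridin-3-yl)methoxy)carbonyl group.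

The step from compound 3 to compound 4 in this assay is expected to be a number 0.03 log units lower from compound 3 to compound 4 (within the scatter), set beside the earlier one because a number 0.03 log units lower from compound 2 to compound 1 (within the scatter) stayed within the scatter. Compound 4 is therefore estimated at 1.87, with a plausible span from 1.55 to 2.2.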

Compound 4, partition coefficient: 1.88
Estimate against measurement, compound 4: 0.01 log units below; measured number inside the range.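

In this assay the 2-nitrophenyl for 4-methoxyphenyl change gives a number 0.02 log units lower from compound 3 to compound 4 (within the scatter) on the core with the ((pyridin-2-yl)methoxy)carbonyl group and a number 0.03 log units lower from compound 2 to compound 1 (within the scatter) on the core with the ((pyridin-3-yl)methoxy)carbonyl group, so on both cores shown the two compounds of the pair cannot be told apart, and the pyridine change likewise recurs beyond the scatter as a number 0.37 log units higher from compound 1 to compound 4 (beyond the scatter) alongside a number 0.36 log units higher from compound 2 to compound 3 (beyond the scatter) in the other pair. This makes the four compounds a consistent square in which each change reads the same on both cores, but two pairs do not show that the aryl change would stay within the scatter on a further core, and a step within the scatter cannot separate a small shift from none. No measurement at hand gives a reason for any of these steps.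

The compounds shown vary only in the aryl group and in the pyridine attachment, so it remains open whether the same reading would hold with an amine or a carboxylic acid in place of the 2-nitrophenyl group. Also open, going by these compounds, is how a longer chain in place of the methyl group would behave on either core.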